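Moving Bromine from 3-Bromophenyl to 2-Bromophenyl, Starting at a Limit

The source may report more compounds than this note shows. Statements on the series, on what has been measured and on what is new or still open speak of the compounds shown alone.

Compound 1 `COc1cc(OC)c(-c2coc3cc(OCC=C(C)C)ccc3c2=O)cc1OC`: 3500 nM
Compound 2 `COc1cc(OC)c(-c2coc3cc(OCc4cccc(Br)c4)ccc3c2=O)cc1OC`: > 10000 nM (a limit, not a number)

Both results come from a functional assay on U-251 cells (Homo sapiens) for antiproliferative activity, read by MTT assay, with a stated time of 24 h; a lower number here means a stronger inhibitor, a higher number a weaker inhibitor. Compound 2 has no exact number and stands at the limit of > 10000 nM in this assay, at which 1 of the 2 values shown sits.

Compound 3 `COc1cc(OC)c(-c2coc3cc(OCc4ccccc4Br)ccc3c2=O)cc1OC` has not yet been measured in this assay. It differs from compound 2 by a single change: 2-bromophenyl in place of 3-bromophenyl on a saturated chain carbon bound to an oxygen on an aromatic ring. In words, 2-bromophenyl takes the place of 3-bromophenyl on a saturated chain carbon bound to an oxygen on an aromatic ring.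

For the measured compounds named here, one measured step bears on this position: an at least 2.8-fold higher number from compound 1 to compound 2 (0.45 log units; beyond the scatter), where 3-bromophenyl replaced 2-methylprop-1-en-1-yl. Going by the values given here, that step exchanged a whole group, so no measurement yet shows what the new bromine position does. Compound 3 keeps a bromophenyl group, and compound 2 has the limit > 10000 nM, so no clear step beyond the scatter is expected, and another limit is quite possible. The estimated step is a step that the limit leaves unreadable from compound 2 to compound 3. For compound 3 the estimated value is 11000 nM, with an expected range from 4000 nM to 30000 nM.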

Compound 3, half-maximal inhibitory concentration: > 10000 nM
Compound 3: no number, only a limit; the forecaster's own chance of this, stated with the estimate: 60%; the middle value lies beyond the limit too.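

In this assay, compound 3 gives > 10000 nM, which is a limit of the assay and not a number. Putting 2-bromophenyl in place of 2-methylprop-1-en-1-yl gives an at least 2.8-fold higher number from compound 1 to compound 3 (0.45 log units; beyond the scatter), so both bromine positions shown now give a higher number, meaning a weaker result, than the 2-methylprop-1-en-1-yl group does. The change from 3-bromophenyl to 2-bromophenyl itself cannot be read, and the move of the bromine has no measured size, as both results stop at the same point: the limit of > 10000 nM in this assay, at which 2 of the 3 values shown sit.

Going by these compounds, how far compound 2 and compound 3 each lie past that limit stays open, and so does whether the bromine position matters at all in this assay. Also open, on these data alone, is whether a phenyl group without bromine, a longer chain or an amine at this place on the saturated chain carbon would bring the number back towards that of compound 1, which would show whether the loss belongs to the bromine or to the ring that carries it.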